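The source may report more compounds than this note shows. Statements on the series, on what has been measured and on what is new or still open speak of the compounds shown alone.

Going by the values given here, in an assay on isolated protein for inhibition of polyamine deacetylase HDAC10 (Homo sapiens) (on this read-out higher numbers stand for weaker inhibition and lower numbers for stronger inhibition), only two compounds have been measured. Compound 1, `O=C(NO)c1ccc(Cn2ccc3cc(C(=O)c4ccc(F)cc4)ccc32)cc1`, reaches only a limit of the assay; in this assay compound 1 gives > 100000 nM. Among the compounds with values here, compound 2, `COc1cccc(C(=O)c2ccc3c(ccn3S(=O)(=O)c3cccc(/C=C/C(=O)NO)c3)c2)c1`, is the one compound with a number: in this assay compound 2 gives 7740 nM. As the limit of > 100000 nM in this assay, at which 1 of the 2 values shown sits, records, this leaves compound 2 as the sole numerical reference point, with nothing to compare it against in the same series.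

Compound 3, `COc1ccc(C(=O)c2ccc3c(ccn3S(=O)(=O)c3cccc(/C=C/C(=O)NO)c3)c2)cc1OC`, differs from compound 2 by methoxy in place of hydrogen on an aromatic carbon; cut one bond further out, the change reads 3-methoxyphenyl to 3,4-dimethoxyphenyl, or (3-methoxyphenyl)carbonyl to (3,4-dimethoxyphenyl)carbonyl. Within the data shown here, no step between measured compounds is available to size such a change, so the expectation rests on compound 2 alone. The author expects the step in this assay to be a 1.2-fold lower number from compound 2 to compound 3 (0.08 log units; within the scatter), that is, no change beyond the usual scatter of the measurement. Compound 3 is accordingly estimated at 6500 nM in this assay, with a range from 2500 nM to 17000 nM.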

Compound 3, half-maximal inhibitory concentration: 8240 nM
Beside the measured number, compound 3's estimate is 1.3-fold (0.10 log units) below it; low and high end bracket the measured number.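

In this assay, going by these compounds alone, methoxy in place of hydrogen on an aromatic carbon, ortho to a methoxy group and para to a large group, gives a 1.1-fold higher number from compound 2 to compound 3 (0.03 log units; within the scatter), the first step that can be sized. The 3-methoxyphenyl group can therefore become 3,4-dimethoxyphenyl with no change beyond the usual scatter, a finding that holds for this one group at this one position and on this core. No measurement shown here bears on why the number stays within the scatter.

Within the data shown here, what remains open is whether this position accepts other groups in the same way, such as an amine, a carboxylic acid or a longer chain like butoxy, since methoxy is the only group that has been placed there. Also open, from the compounds shown here alone, is what the methoxy already present in compound 2 contributes. No compound shown replaces it with hydrogen or moves it while keeping the rest of the structure the same.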